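Swapping a pyridine for a pyrazole on a thiazole acetic acid core

The source may hold more compounds than are shown below. What is called first, only, known or untested is meant among the compounds shown, and "the series" means these compounds.

The study measures antagonism at a prostaglandin receptor in an in vitro functional assay on HEK285-7 cells for antagonist activity at prostaglandin D2 receptor 2 (Homo sapiens), read by BRET and beta-arrestin recruitment; a higher number here means a larger maximal response, a lower number a smaller maximal response. Of the compounds shown here, two have been measured. Compound 1 `COc1cc(-c2nc(C(c3ccc(F)cc3)c3ccc(F)cc3)sc2CC(=O)O)ccn1` gives 60% in this assay. Compound 2 `O=C(O)Cc1sc(C(c2ccccc2)c2ccccc2)nc1-c1ccc(F)c(F)c1` gives 80% in this assay. On these two numbers compound 1 stands lowest, and the gap to compound 2 lies beyond the usual scatter of repeated measurements.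

The next step takes compound 1 to compound 3 `O=C(O)Cc1sc(C(c2ccc(F)cc2)c2ccc(F)cc2)nc1-c1cn[nH]c1`, which has not yet been measured. The change is 1H-pyrazol-4-yl in place of 2-methoxypyridin-4-yl on an aromatic carbon. Among the measured compounds shown here, no measured pair in this set shows the effect of exactly this change, so there is no direct precedent to lean on.

Given that, the step in this assay is expected to be small, with no clear direction beyond the scatter: the estimated step is a number 5 percentage points higher from compound 1 to compound 3 (within the scatter). For compound 3 the expected value in this assay is 65%, in a range from 40% to 90%.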

Compound 3, largest response reached (reported as efficacy), in percent of the reference or control that the assay uses: 80%
Estimate against measurement, compound 3: 15 percentage points below; the measured number falls inside the stated range.
By their numbers in this assay, from the lowest: compound 1; then compounds 2 and 3 (each within the scatter of the next).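

In this assay, 1H-pyrazol-4-yl in place of 2-methoxypyridin-4-yl gives a number 20 percentage points higher from compound 1 to compound 3 (beyond the scatter), so the group on this aromatic carbon, next to the ring nitrogen, can move the maximal response on the shared core. The change is not a single one: a six-membered aromatic ring gives way to a five-membered aromatic ring with 2 hetero atoms, and 1 hydrogen-bond donor enters, so this one step cannot separate those features. Nothing available here explains why the response rises at this position.

A 1-methylpyrazol-4-yl group at the same place would show whether the pyrazole ring hydrogen matters, while a plain pyridin-4-yl group would isolate the part played by the methoxy group. As far as these compounds go, whether a small open-chain group, such as an amine, would fit this position also remains open.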